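A few compounds are considered here, and "the series" means these few. Any claim that something is new, unique, unknown or untested is made for them only; others in the source may bear on it.

Measured so far:
- compound 1 `CN1CCN(C[C@H]2CN(c3ccc(-n4cc(-c5ccccn5)cn4)c(F)c3)C(=O)O2)CC1` — in an ADME assay on L02 cells (Homo sapiens) for cytotoxicity, read by MTT assay, with a stated time of 48 h (a higher number here means a weaker inhibitor, a lower number a stronger inhibitor), compound 1 gives 70 ug/mL.
- compound 2 `O=C1O[C@@H](CN2CCCCC2)CN1c1ccc(-n2cc(-c3ccccn3)cn2)c(F)c1` — in this assay compound 2 returns only a limit, > 400 ug/mL.

Compound 2 therefore sits at the limit of > 400 ug/mL in this assay, at which 1 of the 2 values shown sits, with no number beneath it. Going by the values given here, the one measured step, an at least 5.7-fold higher number from compound 1 to compound 2 (0.75 log units; beyond the scatter), runs toward that limit. Compound 3 `O=C1CSC(=O)N1C[C@H]1CN(c2ccc(-n3cc(-c4ccccn4)cn3)c(F)c2)C(=O)O1` carries 2,4-dioxo-1,3-thiazolidin-3-yl in place of piperidin-1-yl on a saturated chain carbon bound to a saturated ring carbon. Among the compounds with values here, no measured step covers a group of that kind, so the step from compound 2 to compound 3 is taken as open. Compound 3 is estimated at 350 ug/mL, range 120 ug/mL to 900 ug/mL. That estimate means an expected step of an at least 1.1-fold lower number from compound 2 to compound 3 (0.05 log units; that floor lies within the scatter).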

Compound 3, half-maximal inhibitory concentration: > 400 ug/mL
Compound 3 ended at the assay's limit; the forecaster's own chance of this, stated with the estimate: 55%; at least 1.1-fold (0.05 log units) between middle value and limit.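

In this assay, 2,4-dioxo-1,3-thiazolidin-3-yl in place of 4-methylpiperazin-1-yl gives an at least 5.7-fold higher number from compound 1 to compound 3 (0.75 log units; beyond the scatter). The shift away from the value of compound 1 therefore holds for two different replacements at this place, one a six-membered ring and the other a five-membered ring with two hetero atoms. The step between compound 2 and compound 3 cannot be read, as both values are limits: the limit of > 400 ug/mL in this assay, at which 2 of the 3 values shown sit.

From the compounds shown here alone, whether morpholin-4-yl or an open-chain dimethylamino group on the same carbon would stay at the limit or return toward the value of compound 1 remains open.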